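The compounds below may be only part of what the source reports. "The series", "measured", "known", "first", "only" and "open" are said of these compounds alone.

Compounds measured: compound 1 `OC[C@@]1(c2ccc(F)cc2)NC[C@@H](O)[C@@H]1O`, compound 2 `OC[C@]1(c2ccc(F)cc2)NC[C@H](O)[C@H]1O` and compound 3 `CCCCCCCCC[C@@]1(CO)NC[C@H](O)[C@H]1O`.

In an assay on isolated protein for inhibition of lysosomal alpha-glucosidase (Rattus norvegicus), read by colorimetric assay (a lower number here means a stronger inhibitor, a higher number a weaker inhibitor), compound 1 gives 12000 nM, compound 2 gives 101000 nM and compound 3 gives 960 nM. Compound 3 thus has the lowest number of the three in this assay, with compound 1 its nearest neighbour and compound 2 the furthest away.

Compound 4 `CCCCCCCCC[C@]1(CO)NC[C@@H](O)[C@@H]1O` is the one not yet measured. It differs from compound 3 as follows: the two compounds have the same atoms and bonds and differ only in configuration as drawn: 3 of 3 stereo elements differ (all stereocentres are inverted: mirror images); a stereocentre at a saturated ring carbon is drawn S in compound 3 and R in compound 4; a stereocentre at a saturated ring carbon is drawn S in compound 3 and R in compound 4; a stereocentre at a saturated ring carbon is drawn S in compound 3 and R in compound 4. Going by the values given here, only one measured step bears on this change, namely an 8.4-fold higher number from compound 1 to compound 2 (0.93 log units; beyond the scatter), which rests on (the fact that compounds 1 and 2 differ only in the configuration as drawn). In that pair, the ring configuration drawn as in compound 2 carried the higher number, and compound 3 shares that drawn ring configuration with compound 2, while compound 4 shares the drawn ring configuration of compound 1. A step toward a lower number in this assay is therefore expected for compound 4, of a size comparable to the step seen between compound 1 and compound 2, although the aryl and nonyl cores differ and the transfer is uncertain. The expected step is a 3.2-fold lower number from compound 3 to compound 4 (0.51 log units; beyond the scatter). For compound 4 the estimate in this assay is 300 nM, with a range from 60 nM to 1500 nM.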

Compound 4, half-maximal inhibitory concentration: 66000 nM
Beside the measured number, compound 4's estimate is 220-fold (2.34 log units) below it, outside the stated range (above it).
By their numbers in this assay, from the lowest: compound 3; then compound 1; then compounds 4 and 2 (each within the scatter of the next).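

In this assay, inverting all three stereocentres does not have one fixed direction across the two mirror-image pairs: a 69-fold higher number from compound 3 to compound 4 (1.84 log units; beyond the scatter), whereas an 8.4-fold higher number from compound 1 to compound 2 (0.93 log units; beyond the scatter). The drawn ring configuration that carries the higher number in the aryl pair therefore carries the lower number in the nonyl pair, so the preference depends on the group the core carries, and the effect of inversion is also larger in the nonyl pair. The step comes from configuration alone, because nothing else separates this pair: the fact that compounds 3 and 4 differ only in the configuration as drawn

With only these two pairs, the compounds shown leave open what sets the direction of the preference. A shorter alkyl chain, a longer chain or an unsubstituted phenyl ring could side with either pair.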